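The compounds below may be only part of what the source reports. "The series", "measured", "known", "first", "only" and "open" are said of these compounds alone.

Of the compounds shown here, two have been measured in a functional assay on COLO 205 cells (Homo sapiens) for cytotoxicity, read by MTT assay, with a stated time of 48 h; a lower number here means a stronger inhibitor, a higher number a weaker inhibitor.

Compound 1, `Fc1cccc(-c2nc(Nc3ccc(Cl)cc3)c3cc(F)ccc3n2)c1`: 32600 nM
Compound 2, `Nc1cccc(Nc2nc(-c3cccc(F)c3)nc3ccc(F)cc23)c1`: > 50000 nM; this value is a limit of the assay, not a number.

Compound 2 therefore stands at the ceiling of what this assay reports, and only that much is known of it. Within the data shown here, the single measured step, an at least 1.5-fold higher number from compound 1 to compound 2 (0.18 log units; that floor lies within the scatter), runs toward weaker inhibition, though its floor lies within the usual scatter. Compound 3, `Nc1ccccc1Nc1nc(-c2cccc(F)c2)nc2ccc(F)cc12`, has the same atoms as compound 2, joined differently: 2-aminophenyl in place of 3-aminophenyl on a nitrogen on an aromatic ring. Among the measured compounds shown here, no measured step touches this particular move, so the data give no direction for it. The expected step is therefore small, a step that the limit leaves unreadable from compound 2 to compound 3, with little prospect of a numerical reading rather than a limit. The estimate for compound 3 is 60000 nM, spanning 20000 nM to 200000 nM.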

Compound 3, half-maximal inhibitory concentration: > 50000 nM
Compound 3 gave a limit, no number (the forecaster's own chance of this, stated with the estimate: 70%); the middle value does not contradict the limit.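

Compound 3 gives > 50000 nM in this assay, which is a limit of the assay and not a number. Compound 2 carries the same limit, so the step between them cannot be read, and moving the amino group from 3-aminophenyl to 2-aminophenyl on this nitrogen has no measurable outcome here. The change from 4-chlorophenyl to 2-aminophenyl gives an at least 1.5-fold higher number from compound 1 to compound 3 (0.18 log units; that floor lies within the scatter), so this second aminophenyl group also fails to establish a real loss of activity relative to compound 1.

On these data alone, what remains open is how weak either aminophenyl compound truly is, since the readings stop at one ceiling: the limit of > 50000 nM in this assay, at which 2 of the 3 values shown sit. Also open, as far as these compounds go, is how a different group at this position would read, such as 4-methoxyphenyl or a phenyl ring bearing a carboxylic acid.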